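Moving the substituent around a pendant aryl ring

The compounds below may be only part of what the source reports. "The series", "measured", "known", "first", "only" and "open" are said of these compounds alone.

Compound 1 `COc1ccc(-c2nc3cccc(-c4cc(OC)c(OC)c(OC)c4)c3o2)cc1`: 3500 nM
Compound 2 `COc1cccc(-c2nc3cccc(-c4cc(OC)c(OC)c(OC)c4)c3o2)c1`: > 25000 nM
Compound 3 `COc1ccc(-c2nc3cccc(-c4cc(OC)c(OC)c(OC)c4)c3o2)cc1F`: 2800 nM

In a functional assay on NCI-H460 cells (Homo sapiens) for antiproliferative activity, read by MTT assay, with a stated time of 48 h (on this read-out lower numbers stand for stronger inhibition and higher numbers for weaker inhibition), compound 1 gives 3500 nM, the highest of the two numbers shown; compound 3 gives 2800 nM, and the gap between these two values lies inside the usual scatter. Compound 2 reaches only a limit of this assay, > 25000 nM, as the limit of > 25000 nM in this assay, at which 1 of the 3 values shown sits, records. Compound 4 `COc1cc(-c2cccc3nc(-c4cccc(C)c4)oc23)cc(OC)c1OC` differs from compound 1 by 3-methylphenyl in place of 4-methoxyphenyl on an aromatic carbon. The step that bears on this is an at least 7.1-fold higher number from compound 1 to compound 2 (0.85 log units; beyond the scatter), where the substituent also left its original place for another on the pendant ring; the step of a 1.3-fold lower number from compound 1 to compound 3 (0.10 log units; within the scatter) kept the 4-methoxy group and stayed within the scatter. A weaker result is therefore expected for compound 4, with a 5.7-fold higher number from compound 1 to compound 4 (0.76 log units; beyond the scatter) likely, and possibly only a limit again. The estimate for compound 4 is 20000 nM, ranging from 6000 nM to 60000 nM.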

Compound 4, half-maximal inhibitory concentration: > 25000 nM
Compound 4 ended at the assay's limit; the forecaster's own chance of this, stated with the estimate: 50%; middle value at least 1.2-fold (0.09 log units) away from the limit.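

Compound 4 records only a limit in this assay, not a number, as compound 2 does: the limit of > 25000 nM in this assay, at which 2 of the 4 values shown sit. The steps are an at least 7.1-fold higher number from compound 1 to compound 4 (0.85 log units; beyond the scatter) and an at least 8.9-fold higher number from compound 3 to compound 4 (0.95 log units; beyond the scatter), so the loss seen with the 3-methoxyphenyl group of compound 2 also appears with 3-methylphenyl, a group without oxygen. The step between compound 2 and compound 4 cannot be read from two limits. From the compounds shown here alone, whether an amine or a hydroxyl group in place of the methyl of compound 4 would give a measurable number stays open.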